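The compounds below may be only part of what the source reports. "The series", "measured", "known", "first", "only" and "open" are said of these compounds alone.

Of the compounds shown here, two have numbers so far in a physicochemical assay for solubility, with a stated time of 4 h, at pH 2.0 (on this read-out lower numbers stand for lower solubility and higher numbers for higher solubility), and they lie far apart. Compound 1 (`CNC(=O)c1cc(N)c(Nc2ccc(C#N)cc2)cc1Oc1c(C)cc(CCC#N)cc1C`) gives 44.7 ug/mL there, while compound 2 (`Cc1cc(/C=C/C#N)cc(C)c1Oc1cc(Nc2ccc(C#N)cc2)c(N)cc1C(F)(F)F`) gives 0.42 ug/mL and so holds the lower of the two numbers, with a gap well beyond the usual scatter of repeated measurements. Next comes compound 3 (`CNC(=O)c1cc(N)c(Nc2ccc(C#N)cc2)cc1Oc1c(C)cc(/C=C/C#N)cc1C`), which is still unmeasured. It differs from compound 2 in one place, with methylcarbamoyl in place of trifluoromethyl on an aromatic carbon, para to a (4-cyanophenyl)amino group. For the measured compounds named here, no measured pair isolates this swap, so any forecast rests on thin ground. Going by the values given here, the one hint is compound 1, which also carries methylcarbamoyl and stands at 44.7 ug/mL on this scale. A rise beyond the scatter is therefore expected, though one compound makes no pattern. What is expected is a 36-fold higher number from compound 2 to compound 3 (1.55 log units; beyond the scatter) in this assay, a large but uncertain move. For compound 3 the estimated value is 15 ug/mL (expected range 3 ug/mL to 60 ug/mL) once it is measured.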

Compound 3, solubility: 8.63 ug/mL
The estimate for compound 3 lay 1.7-fold (0.24 log units) above the measured number, within the range that was stated.
By their numbers in this assay, from the lowest: compound 2; then compound 3; then compound 1.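

For the compounds shown here, this pair gives the first direct reading of the swap at this position: in this assay, methylcarbamoyl in place of trifluoromethyl, on the aromatic carbon para to a (4-cyanophenyl)amino group, brings a 21-fold higher number from compound 2 to compound 3 (1.31 log units; beyond the scatter) and counts as a large step. Compound 3 also connects to compound 1 through a single change elsewhere in the molecule, where 2-cyanoethenyl in place of 2-cyanoethyl goes with a 5.2-fold lower number from compound 1 to compound 3 (0.71 log units; beyond the scatter) as a more modest step. Both changes therefore move the number beyond the scatter, the swap on the aromatic carbon by more than the change in the chain, although each size comes from a single pair of compounds.

As far as these compounds go, it remains open whether other groups on that aromatic carbon, such as a carboxylic acid or a simple amine, would give a number near that of methylcarbamoyl, and whether the same swap would give a step of similar size with 2-cyanoethyl in place of 2-cyanoethenyl. No measurement at hand says why either step occurs.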